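Triazole substituent variation on the shared lactone core

The source may report more compounds than this note shows. Statements on the series, on what has been measured and on what is new or still open speak of the compounds shown alone.

Measured so far in a functional assay on HeLa cells (Homo sapiens) for antiproliferative activity, read by MTT assay, with a stated time of 72 h; a lower number here means a stronger inhibitor, a higher number a weaker inhibitor:
- compound 1 `CC(C)(C)c1cn(C[C@H](O)[C@H]2OC(=O)C(OCc3ccccc3)=C2OCc2ccccc2)nn1`: compound 1 gives 18300 nM
- compound 2 `C[Si](C)(C)c1cn(C[C@H](O)[C@H]2OC(=O)C(OCc3ccccc3)=C2OCc2ccccc2)nn1`: compound 2 gives 22300 nM
- compound 3 `O=C1O[C@H]([C@@H](O)Cn2cc(CCO)nn2)C(OCc2ccccc2)=C1OCc1ccccc1`: compound 3 gives 68800 nM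

Compound 3 has the highest number of the three, and both of its steps from the other two are beyond the scatter: a 3.8-fold higher number from compound 1 to compound 3 (0.58 log units; beyond the scatter) and a 3.1-fold higher number from compound 2 to compound 3 (0.49 log units; beyond the scatter). The step between compound 1 and compound 2 is small, a 1.2-fold higher number from compound 1 to compound 2 (0.09 log units; within the scatter).

Compound 4 `CCCCCc1ccc(-c2cn(C[C@H](O)[C@H]3OC(=O)C(OCc4ccccc4)=C3OCc3ccccc3)nn2)cc1` differs from compound 3 only at the triazole carbon: 4-pentylphenyl in place of 2-hydroxyethyl on an aromatic carbon. The two steps that bear on this position, 1>3 and 2>3, both show that replacing the 2-hydroxyethyl group by a carbon-only or silicon-containing group without donors or acceptors is linked to a lower number. Compound 4 carries a much larger carbon-only group in this place, with no donor or acceptor, so a modest lower number relative to compound 3 is expected, about the size of those two steps; whether the larger size of 4-pentylphenyl pushes the number further down is not told by any of the measured compounds. The estimated step is a 4.9-fold lower number from compound 3 to compound 4 (0.69 log units; beyond the scatter). For compound 4 the expected value in this assay is 14000 nM, with a range from 4000 nM to 45000 nM.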

Compound 4, half-maximal inhibitory concentration: 8390 nM
Beside the measured number, compound 4's estimate is 1.7-fold (0.22 log units) above it; low and high end bracket the measured number.
By their numbers in this assay, from the lowest: compound 4; then compounds 1 and 2 (each within the scatter of the next); then compound 3.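

In this assay, for the compounds shown here, this aromatic carbon carries a far larger group than in the earlier compounds, and 4-pentylphenyl gives the lowest number of the four, with the largest step from 2-hydroxyethyl (an 8.2-fold lower number from compound 3 to compound 4 (0.91 log units; beyond the scatter)). The earlier compounds shown here showed only that tert-butyl and its silicon-containing counterpart stand below 2-hydroxyethyl; the new steps (a 2.2-fold lower number from compound 1 to compound 4 (0.34 log units; beyond the scatter); a 2.7-fold lower number from compound 2 to compound 4 (0.42 log units; beyond the scatter)) show that the number can fall further with a group of 11 carbon atoms holding a six-membered aromatic ring, and that the number does not rise at this size. Nothing measured explains why the number falls with this change.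

Since the ring and the pentyl chain enter together, the series does not show which part goes with the lower number, and phenyl without the chain, or a ring with a shorter or longer chain, would separate them. From the compounds shown here alone, how an amine or a carboxylic acid at the end of that chain would compare with the 4-pentylphenyl group also remains open.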